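A Benzyloxy Swap Predicted on a Urea Scaffold

This account rests on a few compounds, and the source may have more. Where it says the series, first, only, none or still open, it means among the compounds named here.

Compound 2 `O=S(=O)(NCCNC(=S)Nc1cc(C(F)(F)F)cc(C(F)(F)F)c1)c1ccc(-c2ccccc2Oc2ccc(O)c(O)c2)s1` gives 18300 nM in a functional assay on HL-60 cells (Homo sapiens) for inhibition, read by CCK-8 assay, with a stated time of 48 h; on this read-out lower numbers stand for stronger inhibition and higher numbers for weaker inhibition. Compound 1 `O=S(=O)(NCCNC(=S)Nc1cc(C(F)(F)F)cc(C(F)(F)F)c1)c1ccc(-c2ccccc2OCc2ccccc2)s1` differs from it by benzyl in place of 3,4-dihydroxyphenyl on an oxygen on an aromatic ring, and in this assay compound 1 gives 2100 nM, so that an 8.7-fold lower number from compound 2 to compound 1 (0.94 log units; beyond the scatter). Compound 3 `O=C(NCCNS(=O)(=O)c1ccc(-c2ccccc2Oc2ccc(O)c(O)c2)s1)Nc1cc(C(F)(F)F)cc(C(F)(F)F)c1` carries the same ether substituent as compound 2 but a different core; the difference between the two cores is not broken down here. In this assay compound 3 gives 10500 nM, which lies within the scatter of the value of compound 2, so the two are not distinguished. Compound 4 `O=C(NCCNS(=O)(=O)c1ccc(-c2ccccc2OCc2ccccc2)s1)Nc1cc(C(F)(F)F)cc(C(F)(F)F)c1` has not yet been measured. It differs from compound 3 by benzyl in place of 3,4-dihydroxyphenyl on an oxygen on an aromatic ring, the same change at the same place as that between compound 2 and compound 1. Because that single pair showed an 8.7-fold lower number from compound 2 to compound 1 (0.94 log units; beyond the scatter), a step of similar size is expected here, estimated as a 7.0-fold lower number from compound 3 to compound 4 (0.85 log units; beyond the scatter). This rests on one pair only, and the cores differ. Compound 4 is accordingly estimated at 1500 nM, with a plausible range from 500 nM to 5000 nM.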

Compound 4, half-maximal inhibitory concentration: 11400 nM
Compound 4: middle estimate off by 7.6-fold (0.88 log units), on the low side; the measured number lies above the stated range.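

In this assay, placing benzyl instead of 3,4-dihydroxyphenyl on the ether oxygen gives a 1.1-fold higher number from compound 3 to compound 4 (0.04 log units; within the scatter), so the change does not separate the two compounds on this core. The step seen on the core of compound 2 therefore did not carry over to the core of compound 3, and the two readings of the same change disagree: the same change on two cores in this assay, an 8.7-fold lower number (0.94 log units; beyond the scatter) from compound 2 to compound 1 and a 1.1-fold higher number (0.04 log units; within the scatter) from compound 3 to compound 4, 9.5-fold (0.98 log units) apart, beyond the scatter of two such steps. Going by these compounds alone, this shows that the effect of the change cannot be assumed to transfer between these two cores, but with only one pair on each core it does not show which feature of the cores accounts for the disagreement, or how the change would behave on any other core.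

The compounds shown leave open whether the step on the core of compound 2 depends on the benzyl group itself or on the loss of the two hydroxyl groups. They also leave open how a plain phenyl, a longer chain ending in phenyl, or a carboxylic acid in place of the benzyl would read on each core.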